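The compounds below may be only part of what the source reports. "The series", "measured", "known", "first", "only" and "open" are said of these compounds alone.

Measured in a functional assay on B16 cells (Mus musculus) for antiproliferative activity, with a stated time of 72 h; on this read-out lower numbers stand for stronger inhibition and higher numbers for weaker inhibition:
- Compound 1 `OC[C@H]1O[C@@H](n2cnc3c(NCc4ccccc4F)ncnc32)[C@H](O)[C@@H]1O`: > 166000 nM
- Compound 2 `OC[C@H]1O[C@@H](n2cnc3c(NCc4ccc(F)cc4)ncnc32)[C@H](O)[C@@H]1O`: "not determined" (no result reported)
- Compound 3 `COc1ccc(CNc2ncnc3c2ncn3[C@@H]2O[C@H](CO)[C@@H](O)[C@H]2O)c(OC)c1`: "not determined" (no result reported)

The entry for compound 1 is a limit and not a number. On these data alone, compound 3 has no single number, so its standing stays open; the only bound nearby is the limit of > 166000 nM in this assay, at which 1 of the 3 values shown sits.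

The next compound is compound 4 `OC[C@H]1O[C@@H](n2cnc3c(NCc4ccc(F)cc4Cl)ncnc32)[C@H](O)[C@@H]1O`. The change is 2-chloro-4-fluorophenyl in place of 2,4-dimethoxyphenyl on a saturated chain carbon bound to a nitrogen on an aromatic ring.

For the measured compounds named here, no measured step exists to size this change, and no step beyond the scatter is expected from it. The expectation of weak inhibition rests on compound 1 alone, with its limit of > 166000 nM. For compound 4 the estimated value is 60000 nM, with an expected range from 5000 nM to 200000 nM.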

Compound 4, half-maximal inhibitory concentration: > 166000 nM
Compound 4 was reported as a limit; the forecaster's own chance of this, stated with the estimate: 45%; at least 2.7-fold (0.44 log units) between middle value and limit.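

No new step can be read: compound 1 and compound 4 both stand only as limits in this assay. Left open is whether any compound shown gives a single number, and whether the phenyl substituents change it: the limit of > 166000 nM in this assay, at which 2 of the 4 values shown sit.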